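From a dimethylamino chain to a propyl chain

This account rests on a few compounds, and the source may have more. Where it says the series, first, only, none or still open, it means among the compounds named here.

Compound 1 `COc1ncc(-c2ccc3nc(NC(=O)N4CCCC4)nn3c2)cc1NS(=O)(=O)c1ccc(F)cc1`: 1690 nM
Compound 2 `COc1ncc(-c2ccc3nc(NC(=O)NCCN(C)C)nn3c2)cc1NS(=O)(=O)c1ccc(F)cc1`: 980 nM

Within the data shown here, in a functional assay on U-87MG ATCC cells for cytotoxicity against U-87 MG (Homo sapiens), read by MTT assay, with a stated time of 72 h (on this read-out higher numbers stand for weaker inhibition and lower numbers for stronger inhibition), compound 2 stands within the scatter of compound 1, the only other measured compound. Compound 3 `CCCNC(=O)Nc1nc2ccc(-c3cnc(OC)c(NS(=O)(=O)c4ccc(F)cc4)c3)cn2n1` has not yet been measured, and it differs from compound 2 in one place: methyl in place of dimethylamino on a saturated chain carbon, two bonds along the chain from an amide-type nitrogen. Methyl takes the place of dimethylamino on a saturated chain carbon, two bonds along the chain from an amide-type nitrogen, so 2-(dimethylamino)ethyl becomes propyl. Just one measured step is available as a guide: a 1.7-fold lower number from compound 1 to compound 2 (0.24 log units; within the scatter). Among the measured compounds shown here, that step swapped a different pair of groups, so it bears on this change only loosely, and no measured compound carries the propyl chain. For the measured compounds named here, with that step as the only guide, no change beyond the scatter is expected in this assay. The estimated step is a 1.3-fold higher number from compound 2 to compound 3 (0.12 log units; within the scatter). For compound 3 the estimated value is 1300 nM, with an expected range from 500 nM to 3500 nM.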

Compound 3, half-maximal inhibitory concentration: 420 nM
Estimate against measurement, compound 3: 3.1-fold (0.49 log units) above; measured number outside the range, below it.
By their numbers in this assay, from the lowest: compound 3; then compounds 2 and 1 (each within the scatter of the next).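

In this assay, replacing dimethylamino with methyl on a saturated chain carbon, two bonds along the chain from an amide-type nitrogen, gives a 2.3-fold lower number from compound 2 to compound 3 (0.37 log units; beyond the scatter) and so moves the number beyond the scatter. The earlier swap of pyrrolidin-1-yl for (2-(dimethylamino)ethyl)amino on a carbonyl carbon stayed within the scatter, whereas propylamino in that place gives a 4.0-fold lower number from compound 1 to compound 3 (0.60 log units; beyond the scatter) and shows that the group held on this carbonyl carbon can shift the number. Among these three compounds, the lowest number belongs to compound 3, whose propyl chain carries no dimethylamino, so that group is not needed to reach this level of cell killing.

Nothing shown explains why the number falls with this change. Going by these compounds, it also remains open whether a shorter ethyl chain, a longer butyl chain, or a propyl chain ending in a hydroxyl group would lower the number further or raise it.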